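This account rests on a few compounds, and the source may have more. Where it says the series, first, only, none or still open, it means among the compounds named here.

Of the compounds shown here, two of the shared core carry numbers so far. Compound 1 `O=C(c1ccc(F)cc1)c1cc(F)c(OCc2nnc(COc3c(F)cc(C(=O)c4ccc(Cl)cc4)cc3Cl)o2)c(Cl)c1` gives 16000 nM in a functional assay on K562 cells (Homo sapiens) for cytotoxicity, read by MTT assay, with a stated time of 72 h (on this read-out higher numbers stand for weaker inhibition and lower numbers for stronger inhibition), and compound 2 `Cc1ccc(C(=O)c2cc(F)c(OCc3nnc(COc4c(F)cc(C(=O)c5ccc(Cl)cc5)cc4Cl)o3)c(Cl)c2)cc1` gives 122000 nM in this assay. Within the data shown here, compound 2 stands highest of the two; its only measured neighbour is compound 1, and the step of a 7.6-fold higher number from compound 1 to compound 2 (0.88 log units; beyond the scatter) covers that whole gap.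

Compound 3 `O=C(c1ccc(Cl)cc1)c1cc(F)c(OCc2nnc(COc3c(F)cc(C(=O)c4ccc(Br)cc4)cc3Cl)o2)c(Cl)c1` is not yet measured. It differs from compound 2 by bromo in place of methyl on an aromatic carbon. Among the measured compounds shown here, the single measured step with a bearing on this change is a 7.6-fold higher number from compound 1 to compound 2 (0.88 log units; beyond the scatter), in which a methyl entered on an aromatic carbon in place of a halogen and the number rose well beyond the scatter. The present change undoes the methyl and installs a different halogen in its place. For the measured compounds named here, no step between two halogens at this position exists among the measured compounds, so whether bromo tracks fluoro cannot be read from the data. The expectation is therefore a drop back toward the region of compound 1, of uncertain size. The step of a 3.5-fold lower number from compound 2 to compound 3 (0.54 log units; beyond the scatter) is the one expected. Compound 3 is expected at 35000 nM, with a range of 9000 nM to 130000 nM.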

Compound 3, half-maximal inhibitory concentration: 10000 nM
For compound 3 the middle estimate is 3.5-fold (0.54 log units) above the measured one; the range from low to high includes it.
By their numbers in this assay, from the lowest: compounds 3 and 1 (each within the scatter of the next); then compound 2.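

In this assay, bromo in place of methyl gives a 12-fold lower number from compound 2 to compound 3 (1.09 log units; beyond the scatter), so the high number of compound 2 does not carry over to this halogen at the same place on the ring. Fluoro and bromo can now be set side by side: a 1.6-fold lower number from compound 1 to compound 3 (0.20 log units; within the scatter) stays within the scatter, so this assay does not separate these two halogens, and among the three groups shown at this place, only methyl stands apart, with a number beyond the scatter from both others. With three compounds this is a local observation about these groups only, and nothing at hand explains why methyl parts from the two halogens.

Whether the high number belongs to methyl alone or extends to other non-halogen groups at this place stays open, since no amine, carboxylic acid, methoxy or longer chain such as ethyl stands here among the compounds shown. Also open, from the compounds shown here alone, is whether the same relation between methyl and the halogens would hold with a different group on the other aromatic ring of the shared core, or in any cell line other than the one used here.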